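The source may report more compounds than this note shows. Statements on the series, on what has been measured and on what is new or still open speak of the compounds shown alone.

Three compounds share the same core. Compound 1 `CCCCCCCCOc1nc(N)nc2c1ncn2/C=C1/CC1(CO)CO` carries an octyloxy group on an aromatic carbon, compound 2 `Nc1nc(NC2CCCCC2)c2ncn(/C=C3/CC3(CO)CO)c2n1` a cyclohexylamino group at that place, and compound 3 `CCCCCOc1nc(N)nc2c1ncn2/C=C1/CC1(CO)CO` a pentyloxy group there. In an ADME assay on HFF cells (Homo sapiens) for cytotoxicity, with a stated time of 8 days (on this read-out higher numbers stand for lower toxicity in this test and lower numbers for higher toxicity in this test), compound 1 reaches only the limit of the assay, > 300000 nM, and not a number. Compound 2 likewise stands at a limit in this assay, > 300000 nM, which is where (the limit of > 300000 nM in this assay, at which 2 of the 3 values shown sit). Compound 3 gives a number in this assay, 259000 nM. The step that the two limits leave unreadable from compound 1 to compound 2, and an at least 1.1-fold lower number from compound 1 to compound 3 (0.06 log units; that floor lies within the scatter) and an at least 1.1-fold lower number from compound 2 to compound 3 (0.06 log units; that floor lies within the scatter) are floors that do not leave the scatter.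

Compound 4 `Nc1nc(OCC(F)(F)F)c2ncn(/C=C3/CC3(CO)CO)c2n1` is not yet measured. It differs from compound 2 in one place: 2,2,2-trifluoroethoxy in place of cyclohexylamino on an aromatic carbon. Going by the values given here, the one measured step that bears on it, the exchange of cyclohexylamino for an alkoxy group in an at least 1.1-fold lower number from compound 2 to compound 3 (0.06 log units; that floor lies within the scatter), stayed within the scatter, so no step beyond the scatter is expected for a number no higher from compound 2 to compound 4 (the limit leaves the size open). Compound 4 is therefore estimated in this assay at 300000 nM, between 150000 nM and 600000 nM, with a fair chance that only a limit is reported.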

Compound 4, half-maximal cytotoxic concentration: > 300000 nM
Compound 4 was reported as a limit; the forecaster's own chance of this, stated with the estimate: 60%; the middle value sits exactly at the limit.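

Compound 4 is a limit in this assay, so 2,2,2-trifluoroethoxy on this aromatic carbon ends at the same limit as octyloxy and cyclohexylamino, while compound 3, with pentyloxy, is the one exception that gives a number. This extends the limit to a fluorinated chain, and trifluoromethyl in place of butyl on the saturated chain carbon bound to an oxygen on an aromatic ring gives an at least 1.1-fold higher number from compound 3 to compound 4 (0.06 log units; that floor lies within the scatter), so no change is established. The steps to compound 4 from compound 1 and compound 2 cannot be read, because both ends of each step are limits: the limit of > 300000 nM in this assay, at which 3 of the 4 values shown sit.

The compounds shown leave open how far compound 1, compound 2 and compound 4 lie from one another. They also leave open whether a carboxylic acid or a morpholine ring at this place would give a number in this assay.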